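Extending a methyl on the shared core of compound 2

The compounds below may be only part of what the source reports. "The series", "measured", "known", "first", "only" and "open" are said of these compounds alone.

Measured so far:
- compound 1 `c1ccc2c(-c3cnc4[nH]nc(-c5nc6ccccc6[nH]5)c4c3)cncc2c1`: 870 nM
- compound 2 `Cc1cccc2[nH]c(-c3n[nH]c4ncc(-c5cncc6ccccc56)cc34)nc12`: 1720 nM
- compound 3 `COCc1cccc2[nH]c(-c3n[nH]c4ncc(-c5cncnc5)cc34)nc12`: 160 nM

In a functional assay on A-375 cells (Homo sapiens) for antiproliferative activity (a higher number here means a weaker inhibitor, a lower number a stronger inhibitor), compound 2 gives the highest of the three numbers, which is to say the weakest inhibition shown. Its closest neighbour is compound 1, and the step of a 2.0-fold higher number from compound 1 to compound 2 (0.30 log units; within the scatter) stays within the scatter, so the two cannot be told apart with confidence. Going by the values given here, compound 3, which carries a methoxymethyl group and a different aromatic ring at the other end of the core, stands much lower and differs from compound 2 in two places, so no single step links them.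

The unmeasured compound 4 `CC(C)OCc1cccc2[nH]c(-c3n[nH]c4ncc(-c5cncc6ccccc56)cc34)nc12` is built from compound 2 by one change: isopropoxy in place of hydrogen on a saturated chain carbon bound to an aromatic carbon. Among the compounds with values here, the only measured step that touches this region is a 2.0-fold higher number from compound 1 to compound 2 (0.30 log units; within the scatter), which adds the methyl itself and lies within the scatter. Nothing measured isolates what a larger ether chain on that methyl does, and compound 3 mixes that kind of chain with a second change.

The expectation is therefore a step no larger than the scatter, perhaps a modest move toward stronger inhibition, giving a 1.7-fold lower number from compound 2 to compound 4 (0.24 log units; within the scatter). Compound 4 is estimated at 1000 nM in this assay, with a range from 300 nM to 3500 nM.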

Compound 4, half-maximal inhibitory concentration: 910 nM
The estimate for compound 4 lay 1.1-fold (0.04 log units) above the measured number; the measured number falls inside the stated range.
By their numbers in this assay, from the lowest: compound 3; then compounds 1, 4 and 2 (each within the scatter of the next).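

Compound 2 carries only a methyl at this place, while compound 4 shows that a saturated chain carbon bound to an aromatic carbon can also carry isopropoxy, a group of 4 heavy atoms, and in this assay this change gives a 1.9-fold lower number from compound 2 to compound 4 (0.28 log units; within the scatter). Set against the core without any substituent there, the whole isopropoxymethyl group gives a 1.0-fold higher number from compound 1 to compound 4 (0.02 log units; within the scatter), so even this much larger group produces no step that stands clear of repeated-measurement noise in this assay. Hydrogen, methyl and isopropoxymethyl therefore cannot be told apart at this place, which is a flat result and not a demonstrated gain or loss.

On these data alone, compound 3 also has an ether chain on this carbon but differs from compound 4 in two places, so it cannot isolate the effect of the chain, and it remains open whether an amine or a carboxylic acid on the same carbon would give a step beyond the scatter. No supporting measurement bears on this result, so no explanation for it can be offered here.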